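The compounds below may be only part of what the source reports. "The series", "measured", "known", "first", "only" and "open" are said of these compounds alone.

Measured compounds:
Compound 1, `COc1cc(-c2nnc(SCC(=O)c3ccc(C)cc3)n2N2C(=O)c3ccccc3C2=O)cc(OC)c1OC`: 9620 nM
Compound 2, `COc1cc(-c2nnc(SCC(=O)c3ccccc3)n2N2C(=O)c3ccccc3C2=O)cc(OC)c1OC`: > 200000 nM

In a functional assay on MKN-45 cells (Homo sapiens) for cytotoxicity, read by MTT assay, with a stated time of 48 h (a higher number here means a weaker inhibitor, a lower number a stronger inhibitor), compound 1 gives 9620 nM. For compound 2 the result in this assay is a limit of the assay and not a number, > 200000 nM; the record here is the limit of > 200000 nM in this assay, at which 1 of the 2 values shown sits. Compound 2 thus stands at the weak end of the two values shown, and only a boundary is known for it.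

The change from compound 2 to compound 3, `COc1ccc(C(=O)CSc2nnc(-c3cc(OC)c(OC)c(OC)c3)n2N2C(=O)c3ccccc3C2=O)cc1`, is methoxy in place of hydrogen on an aromatic carbon, the place being para to a large group. Within the data shown here, the one measured step that bears on this position is an at least 20-fold higher number from compound 1 to compound 2 (1.31 log units; beyond the scatter), in which removing the methyl from that carbon raised the number by a large amount. Putting a methoxy onto the same carbon is expected to move the number back down, although the limit for compound 2 leaves the size of that movement uncertain. The step is therefore expected to be an at least 13-fold lower number from compound 2 to compound 3 (1.12 log units; beyond the scatter). Compound 3 is expected to come in near 15000 nM, within a range from 3000 nM to 100000 nM.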

Compound 3, half-maximal inhibitory concentration: 37200 nM
The estimate for compound 3 lay 2.5-fold (0.39 log units) below the measured number; the range from low to high includes it.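

In this assay, methoxy in place of hydrogen on the carbon para to a large group gives an at least 5.3-fold lower number from compound 2 to compound 3 (0.73 log units; beyond the scatter), so methyl is no longer the only group shown at this carbon that goes with a lower number than hydrogen. The two groups are not interchangeable, however: methoxy in place of methyl gives a 3.9-fold higher number from compound 1 to compound 3 (0.59 log units; beyond the scatter), which places the methoxy compound between the methyl compound and the unsubstituted one and shows that the read-out at this position depends on which group stands there, not only on whether the carbon carries a group. Compound 2 is recorded as a limit of the assay and not a number, so the full size of the gain over hydrogen stays unknown: the limit of > 200000 nM in this assay, at which 1 of the 3 values shown sits.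

What the compounds shown leave open is whether a chlorine atom, an amine, a hydroxyl or a longer chain such as ethyl or propyl on this same carbon would follow methyl or methoxy, or neither. They also leave open whether the order of hydrogen, methoxy and methyl would hold if the trimethoxyphenyl or the phthalimide part of the shared core were changed.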